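Nitrophenyl in Place of Chlorophenyl on a Shared Core

A few compounds are considered here, and "the series" means these few. Any claim that something is new, unique, unknown or untested is made for them only; others in the source may bear on it.

Compound 1, `O=c1ccc2cc(OCc3cn(-c4ccccc4)nn3)ccc2o1`: 48800 nM
Compound 2, `COc1ccc(-n2cc(COc3ccc4oc(=O)ccc4c3)nn2)cc1`: 32800 nM
Compound 3, `O=c1ccc2cc(OCc3cn(-c4ccccc4Cl)nn3)ccc2o1`: "not determined" (no result reported)

Compounds 1 and 2 were tested in a functional assay on COLO 205 cells (Homo sapiens) for cytotoxicity, read by MTT assay, with a stated time of 48 h; on this read-out higher numbers stand for weaker inhibition and lower numbers for stronger inhibition. Compound 1 gives 48800 nM and compound 2 gives 32800 nM; the step of a 1.5-fold lower number from compound 1 to compound 2 (0.17 log units; within the scatter) shows that the methoxy change left the read-out essentially unchanged. Compound 3 carries a 2-chlorophenyl on the same core, but in this assay compound 3 is recorded as "not determined" (no result reported), so it stands on no value at all.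

Compound 4, `O=c1ccc2cc(OCc3cn(-c4cccc([N+](=O)[O-])c4)nn3)ccc2o1`, differs from compound 3 by 3-nitrophenyl in place of 2-chlorophenyl on an aromatic nitrogen. Going by the values given here, no measured step describes the exchange of a chlorophenyl for a nitrophenyl here, and the only measured step, from compound 1 to compound 2, concerns a methoxy on a different carbon and lies within the scatter. Both measured values sit close together, so a value near theirs is the plain expectation, with a wide range to allow for an untested change.

Compound 4 is therefore expected to give about 40000 nM in this assay, with a plausible range from 15000 nM to 100000 nM.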

Compound 4, half-maximal inhibitory concentration: 36600 nM
The estimate for compound 4 lay 1.1-fold (0.04 log units) above the measured number, and the stated range covers the measured number.
By their numbers in this assay, from the lowest: compounds 2, 4 and 1 (each within the scatter of the next).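

In this assay, adding a nitro to the phenyl on the aromatic nitrogen gives a 1.3-fold lower number from compound 1 to compound 4 (0.12 log units; within the scatter) and exchanging 4-methoxyphenyl for 3-nitrophenyl gives a 1.1-fold higher number from compound 2 to compound 4 (0.05 log units; within the scatter), both within the scatter. Going by these compounds alone, this is the first nitro-bearing group at this position, and with the methoxy step it shows that neither of these two substituents on the phenyl moves the read-out beyond the scatter, while compound 1, compound 2 and compound 4 remain indistinguishable. The compounds shown offer no evidence on why this position responds so little.

Steps involving compound 3 cannot be read, so the place of its 2-chlorophenyl in this series stays open. Also open, from the compounds shown here alone, is whether an amine or a carboxylic acid on the phenyl would shift the read-out beyond the scatter.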